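This account rests on a few compounds, and the source may have more. Where it says the series, first, only, none or still open, it means among the compounds named here.

Measured so far in an assay on HEK293 cells for inhibition of Steryl-sulfatase (Homo sapiens), tested at 0.1 uM; a higher number here means a stronger effect of the compound at the concentration tested, a lower number a weaker effect:
- compound 1 `CCN(Cc1ccc(Br)cc1)c1cccc(C(=O)N2CCc3ccc(OS(N)(=O)=O)cc3C2)c1` gives 24.2%
- compound 2 `CCCN(Cc1ccccc1)c1cccc(C(=O)N2CCc3ccc(OS(N)(=O)=O)cc3C2)c1` gives 23.1%
- compound 3 `NS(=O)(=O)Oc1ccc2c(c1)CN(C(=O)c1cccc(N3CCc4ccccc4C3)c1)CC2` gives 24.1%

Compound 3 stands second highest of these three numbers, yet its value lies within the scatter of both compound 1 and compound 2. Compound 4 `CCN(Cc1ccccn1)c1cccc(C(=O)N2CCc3ccc(OS(N)(=O)=O)cc3C2)c1` has not yet been measured. It differs from compound 3 in one place: ethyl((pyridin-2-yl)methyl)amino in place of 1,2,3,4-tetrahydroisoquinolin-2-yl on an aromatic carbon. Within the data shown here, three measured steps bear on this change, as each of them also replaces the group on that same aromatic carbon by another: a number 1.1 percentage points lower from compound 1 to compound 2 (within the scatter), a number 0.1 percentage points lower from compound 1 to compound 3 (within the scatter) and a number 1 percentage points higher from compound 2 to compound 3 (within the scatter). None of them moved the read-out beyond the scatter, so no step beyond the scatter is expected in this assay here either; the expected step is a number 2.1 percentage points lower from compound 3 to compound 4 (within the scatter). Compound 4 is therefore estimated at 22%, with a range from 10% to 34%.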

Compound 4, a percentage reported as inhibition, at one concentration (the size of the read-out at that concentration, not a potency): 6.5%
Beside the measured number, compound 4's estimate is 15.5 percentage points above it; the measured number lies below the stated range.
By their numbers in this assay, from the lowest: compound 4; then compounds 2, 3 and 1 (each within the scatter of the next).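

In this assay this position is not indifferent to what sits on it: ethyl((pyridin-2-yl)methyl)amino gives a number 17.6 percentage points lower from compound 3 to compound 4 (beyond the scatter) and a number 16.6 percentage points lower from compound 2 to compound 4 (beyond the scatter), although the three earlier groups stayed within the scatter of each other. Pyridin-2-yl in place of 4-bromophenyl gives a number 17.7 percentage points lower from compound 1 to compound 4 (beyond the scatter), so a change on the saturated chain carbon can carry the read-out beyond the scatter. Nothing shown here explains this fall.

From the compounds shown here alone, it remains open whether a plain phenyl, pyridin-3-yl or pyridin-4-yl on that chain carbon would stay with compound 1 or fall with compound 4.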